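Pyridin-4-yl isomer at the cytotoxicity limit

The source may hold more compounds than are shown below. What is called first, only, known or untested is meant among the compounds shown, and "the series" means these compounds.

In an ADME assay on MT4 cells (Homo sapiens) for cytotoxicity, read by XTT assay, with a stated time of 5 days (a lower number here means that less compound is tolerated, a higher number that more compound is tolerated), compound 1 (`CNC(=O)[C@@H](NC(=O)[C@@](O)(CCN(Cc1ccccn1)NC(=O)[C@@H](NC(=O)OC)C(C)(C)C)Cc1ccccc1)C(C)(C)C`) gives > 10000 nM as a limit of the assay. Compound 2 (`CNC(=O)[C@@H](NC(=O)[C@@](O)(CCN(Cc1cccnc1)NC(=O)[C@@H](NC(=O)OC)C(C)(C)C)Cc1ccccc1)C(C)(C)C`) gives > 10000 nM as a limit too, so its standing is known only as a limit. Compound 3 (`CNC(=O)[C@@H](NC(=O)[C@@](O)(CCN(Cc1ccncc1)NC(=O)[C@@H](NC(=O)OC)C(C)(C)C)Cc1ccccc1)C(C)(C)C`) differs from compound 2 by pyridin-4-yl in place of pyridin-3-yl on a saturated chain carbon bound to an amine nitrogen on the same saturated chain carbon. Among the compounds with values here, the one measured step, a step that the two limits leave unreadable from compound 1 to compound 2, has no readable size, and both measured compounds sit at the limit of > 10000 nM in this assay, at which 2 of the 2 values shown sit, here. The expected step that the limit leaves unreadable from compound 2 to compound 3 in this assay is none beyond the scatter, with no direction expected. The estimate for compound 3 is 15000 nM within a range of 8000 nM to 40000 nM in this reading.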

Compound 3, half-maximal cytotoxic concentration: > 10000 nM
Compound 3 gave a limit, no number (the forecaster's own chance of this, stated with the estimate: 90%); the middle value does not contradict the limit.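

No step among compound 1, compound 2 and compound 3 can be read in this assay, since each gives only a limit: the limit of > 10000 nM in this assay, at which 3 of the 3 values shown sit.

As far as these compounds go, whether pyridin-2-yl, pyridin-3-yl and pyridin-4-yl differ at all in half-maximal cytotoxic concentration stays open.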